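This account rests on a few compounds, and the source may have more. Where it says the series, first, only, none or still open, it means among the compounds named here.

Compound 1 `Cc1ccccc1Nc1nnc(Nc2nc(-c3ccc(Cl)cc3)cs2)s1`: 300 mg/kg
Compound 2 `Cc1ccc(Nc2nnc(Nc3nc(-c4ccc(Cl)cc4)cs3)s2)cc1`: 100 mg/kg
Compound 3 `Cc1ccccc1Nc1nnc(Nc2nc(-c3ccc(Br)cc3)cs2)s1`: 300 mg/kg

All three were tested in a functional assay on the whole organism (strain albino) with Mus musculus as the target, in the maximal electroshock model, with a stated time of 4 h; a lower number here means that less compound is needed, a higher number that more compound is needed for the effect. Compound 1 gives 300 mg/kg in this assay, compound 2 gives 100 mg/kg, and compound 3 gives 300 mg/kg. Compound 1 and compound 3 stand level at the digits measured; their cores differ only in one spot, where (bromo in place of chloro on an aromatic carbon), and that difference made no change at the digits printed from compound 1 to compound 3 (within the scatter). The change from compound 1 to compound 2 is 4-methylphenyl in place of 2-methylphenyl on a nitrogen on an aromatic ring, and it made a 3.0-fold lower number from compound 1 to compound 2 (0.48 log units; beyond the scatter).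

Compound 4 `Cc1ccc(Nc2nnc(Nc3nc(-c4ccc(Br)cc4)cs3)s2)cc1` has not yet been measured in this assay. It relates to compound 3 exactly as compound 2 relates to compound 1: 4-methylphenyl in place of 2-methylphenyl on a nitrogen on an aromatic ring, the same change as before, with the same surroundings at the place, occurring twice among the compounds shown. The core of compound 3 differs from that of compound 1 only by the change that made no change at the digits printed from compound 1 to compound 3 (within the scatter), so the earlier step is a reasonable guide. For compound 4 a repeat of that step is expected, namely a 3.0-fold lower number from compound 3 to compound 4 (0.48 log units; beyond the scatter). Compound 4 is therefore estimated at 100 mg/kg, most likely between 50 mg/kg and 300 mg/kg.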

Compound 4, minimum effective dose: 100 mg/kg
Beside the measured number, compound 4's estimate shows no gap at the digits printed; the measured number falls inside the stated range.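

In this assay, 4-methylphenyl in place of 2-methylphenyl on the core of compound 3 gives a 3.0-fold lower number from compound 3 to compound 4 (0.48 log units; beyond the scatter), so the step seen on the core of compound 1 carries over unchanged: the same change on two cores in this assay, a 3.0-fold lower number (0.48 log units; beyond the scatter) from compound 1 to compound 2 and a 3.0-fold lower number (0.48 log units; beyond the scatter) from compound 3 to compound 4, 1.0-fold (0.00 log units) apart, within the scatter of two such steps. Bromo in place of chloro, read on the cores that carry 4-methylphenyl, gives no change at the digits printed from compound 2 to compound 4 (within the scatter), which repeats what was seen on the cores that carry 2-methylphenyl: the same change on two cores in this assay, no change at the digits printed (within the scatter) from compound 1 to compound 3 and no change at the digits printed (within the scatter) from compound 2 to compound 4, 1.0-fold (0.00 log units) apart, within the scatter of two such steps. Together, the four compounds show that these two changes act independently of each other here, but the two cores differ only in one halogen, so this does not show that the methyl shift would carry over to a more different core, nor does it explain why the step occurs.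

From the compounds shown here alone, it remains open whether the same step would appear with fluoro or a nitrile in place of the halogen. Going by these compounds, it is also open how an unsubstituted phenyl, or a ring bearing an ethyl group, an amine or a carboxylic acid instead of methyl, would compare.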